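The source may hold more compounds than are shown below. What is called first, only, known or untested is meant among the compounds shown, and "the series" means these compounds.

Measured so far:
Compound 1, `CC(C)c1ccc(-n2nc(C(=O)O)cc2-c2ccc(OCc3ccccc3)cc2)cc1`, gives 385 nM in an assay for displacement of a labelled ligand from Apoptosis regulator Bcl-2 (Homo sapiens), read by fluorescence polarization, with a stated time of 30 min; on this read-out lower numbers stand for stronger inhibition and higher numbers for weaker inhibition.
Compound 2, `CCOc1ccc(-c2c(NC(=O)c3ccc(C(C)(C)C)cc3)c(C(=O)O)nn2-c2ccc(Oc3ccccc3)cc2)cc1`, gives 406 nM in this assay.

On these two numbers compound 2 and compound 1 sit within the scatter of each other, so neither can be told apart from the other. Compound 3, `CCOc1ccc(-c2c(NC(=O)c3ccc(OCC(C)C)cc3)c(C(=O)O)nn2-c2ccc(Oc3ccccc3)cc2)cc1`, is still to be measured in this assay. Its difference from compound 2 is isobutoxy in place of tert-butyl on an aromatic carbon. For the measured compounds named here, no measured pair shows such a change, so the step from compound 2 to compound 3 in this assay is expected to be small, with no direction beyond the scatter, a 1.0-fold lower number from compound 2 to compound 3 (0.01 log units; within the scatter). Compound 3 is thus estimated at 400 nM, within 150 nM to 1100 nM.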

Compound 3, inhibition constant: 1040 nM
Beside the measured number, compound 3's estimate is 2.6-fold (0.41 log units) below it; the range from low to high includes it.
By their numbers in this assay, from the lowest: compounds 1 and 2 (each within the scatter of the next); then compound 3.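

Replacing tert-butyl with isobutoxy on this aromatic carbon, para to a large group, gives a 2.6-fold higher number from compound 2 to compound 3 (0.41 log units; beyond the scatter) in this assay, so weaker inhibition. This position is therefore not indifferent to the group it carries, which compounds 1 and 2 alone could not show, as they differ in more than one place. Nothing measured here bears on why the number rises.

On these data alone, it remains open whether isobutyl without the oxygen, a methoxy or an amine at this carbon would move the number, and in which direction.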